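Chain extension on the ether of compound 1: expected step

This account rests on a few compounds, and the source may have more. Where it says the series, first, only, none or still open, it means among the compounds named here.

Compound 1 `CCOCCOc1cccc2ccc(N)nc12` carries a short ether on the shared core and gives in an assay on cells with melanin-concentrating hormone receptor 1 (Homo sapiens) as the target, read by radioligand binding (on this read-out higher numbers stand for weaker inhibition and lower numbers for stronger inhibition), only a limit, > 2000 nM, not a number. Compound 2 `CC(CC(C)(C)C)Oc1cccc2ccc(N3CCCCC3)nc12` also stops at a limit in this assay, > 2000 nM. Within the data shown here, compound 3 `CC(COC(C)(C)C)Oc1cccc2ccc(N)nc12` is the one member of the set with a measured number, 306 nM in this assay. Compound 1 thus stands at the weak end of what is shown, and with it sits compound 2; the point of reference is the limit of > 2000 nM in this assay, at which 2 of the 3 values shown sit, so no step between measured compounds can be sized here.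

The change to compound 4 `COCCOCCOc1cccc2ccc(N)nc12` is methoxy in place of hydrogen on a saturated chain carbon, two bonds along the chain from an oxygen on a saturated carbon. It lengthens the ether chain by a single acceptor without adding any ring or charge.

Among the measured compounds shown here, compound 3, whose chain carries a larger branched ether, is the only compound that reaches a number, and compound 1 with a plain ethoxy does not; the two differ in more than one place, so what carries the difference is not separable. For compound 4 the expectation is that the step that the limit leaves unreadable from compound 1 to compound 4 is small, with compound 4 staying near the limit. The estimated value for compound 4 is 3000 nM, within a range from 800 nM to 12000 nM.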

Compound 4, half-maximal inhibitory concentration: > 2000 nM
Compound 4: only a limit was reported; the forecaster's own chance of this, stated with the estimate: 65%; the middle value lies beyond the limit too.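

Compound 1 and compound 4 both stop at a limit in this assay, not at a number, so no step between them can be read: the limit of > 2000 nM in this assay, at which 3 of the 4 values shown sit.

The compounds shown leave open what values compound 1 and compound 4 actually have, and so whether methoxy in place of hydrogen on this chain changes anything in this assay.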